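A few compounds are considered here, and "the series" means these few. Any claim that something is new, unique, unknown or untested is made for them only; others in the source may bear on it.

Measured compounds:
- Compound 1 `COc1ccc(-n2ccc(=O)c(C(=O)Nc3ccc(Oc4ccnc5c4ccn5C)c(F)c3)n2)cc1`: in a functional assay on A549 cells (Homo sapiens) for cytotoxicity, read by MTT assay, with a stated time of 72 h (a lower number here means a stronger inhibitor, a higher number a weaker inhibitor), compound 1 gives > 60000 nM, a limit of the assay rather than a number.
- Compound 2 `Cc1cc(=O)n(-c2ccc(F)cc2)nc1C(=O)Nc1ccc(Oc2ncnc3[nH]ccc23)cc1`: in this assay compound 2 gives > 60000 nM, again a limit.
- Compound 3 `Cc1cc(=O)n(-c2cccc(F)c2)nc1C(=O)Nc1ccc(Oc2ncnc3[nH]ccc23)cc1`: in this assay compound 3 gives 34800 nM.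

Among the compounds with values here, compound 3 holds the only number among the three; the other two sit at a limit (the limit of > 60000 nM in this assay, at which 2 of the 3 values shown sit). Within the data shown here, the one measured step, an at least 1.7-fold lower number from compound 2 to compound 3 (0.23 log units; that floor lies within the scatter), comes from moving the fluorine on the phenyl ring, and its floor lies within the scatter, so it tells little.

Compound 4 `Cc1ccc(-n2nc(C(=O)Nc3ccc(Oc4ncnc5[nH]ccc45)cc3)c(C)cc2=O)cc1` carries 4-methylphenyl in place of 3-fluorophenyl on an aromatic nitrogen. The group that enters is substituted at the same position as the 4-fluorophenyl of compound 2, whose value was a limit. On that footing, a step back toward weaker inhibition, or none beyond the scatter, is expected. Compound 4 is therefore estimated at 50000 nM, between 20000 nM and 120000 nM, with a real chance that only a limit is reported. The expected step is a 1.4-fold higher number from compound 3 to compound 4 (0.16 log units; within the scatter).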

Compound 4, half-maximal inhibitory concentration: 6400 nM
Compound 4: the middle estimate sits 7.8-fold (0.89 log units) above what was measured; measured number outside the range, below it.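

With a 5.4-fold lower number from compound 3 to compound 4 (0.74 log units; beyond the scatter), the group on this ring nitrogen is shown for the first time to change the result in this assay by more than the scatter, which the earlier move of the fluorine could not establish. Holding the substituent at the same ring position and changing only its identity, 4-methylphenyl against 4-fluorophenyl, gives an at least 9.3-fold lower number from compound 2 to compound 4 (0.97 log units; beyond the scatter), so methyl and fluoro are not interchangeable there. The true size of that step stays unknown, as one end of it is a limit and not a number: the limit of > 60000 nM in this assay, at which 2 of the 4 values shown sit.

Open, from the compounds shown here alone, is whether the gain is particular to methyl or extends to other groups at that position, such as the ethyl of a 4-ethylphenyl or the amine of a 4-aminophenyl. Also open, going by these compounds, is whether a 3-methylphenyl would match the 4-methylphenyl of compound 4.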